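A few compounds are considered here, and "the series" means these few. Any claim that something is new, unique, unknown or untested is made for them only; others in the source may bear on it.

Measured compounds:
compound 1 `CC/C(=C(/c1ccc(/C=C/C(=O)O)cc1)c1ccc2[nH]ncc2c1)c1ccccc1` gives 7.2 nM
compound 2 `CCC/C(=C(/c1ccc(/C=C/C(=O)O)cc1)c1ccc2[nH]ncc2c1)c1ccccc1` gives 11 nM
compound 3 `O=C(O)/C=C/c1ccc(/C(=C(\c2ccccc2)C2CCCC2)c2ccc3[nH]ncc3c2)cc1` gives 10 nM

The three measured compounds share a core and differ only in the alkyl group on the double-bonded chain carbon. In a functional assay on MCF7 cells (Homo sapiens) for cytotoxicity, read by CellTiter-Glo, with a stated time of 5 days (a lower number here means a stronger inhibitor, a higher number a weaker inhibitor), compound 1 gives 7.2 nM, and its number lies within the scatter of the other two: a 1.5-fold higher number from compound 1 to compound 2 (0.18 log units; within the scatter) and a 1.4-fold higher number from compound 1 to compound 3 (0.14 log units; within the scatter). Compound 4 `CC/C(=C(/c1ccc(/C=C/C(=O)O)cc1)c1ccc2[nH]ncc2c1C#N)c1ccccc1` is the unmeasured analogue of compound 1, carrying (cyano in place of hydrogen on an aromatic carbon). For the measured compounds named here, none of the measured steps touches this aromatic position; all concern the alkyl group, and a 1.1-fold lower number from compound 2 to compound 3 (0.04 log units; within the scatter) also stays within the scatter. Going by the values given here, no measured step therefore bears on the change, and the expectation for compound 4 rests on compound 1 alone. Compound 4 is expected to give 10 nM, with a range from 3 nM to 40 nM, meaning an expected step of a 1.4-fold higher number from compound 1 to compound 4 (0.14 log units; within the scatter) in this assay, small but uncertain.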

Compound 4, half-maximal inhibitory concentration: 1.5 nM
Compound 4: middle estimate off by 6.7-fold (0.82 log units), on the high side; the measured number lies below the stated range.
By their numbers in this assay, from the lowest: compound 4; then compounds 1, 3 and 2 (each within the scatter of the next).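

In this assay, for the compounds shown here, cyano in place of hydrogen on this aromatic carbon gives a 4.8-fold lower number from compound 1 to compound 4 (0.68 log units; beyond the scatter) and so is the only step beyond the scatter, since the alkyl changes among compound 1, compound 2 and compound 3 all stayed within it. This aromatic position, ortho to a fused ring, therefore moves the number more than any alkyl change shown. No measurement here says why. Going by these compounds, whether an amine, a methyl or a fluorine at this position would do the same remains open, as does whether cyano gives a similar step with propyl or cyclopentyl in place of ethyl.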